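Amide aryl swap: 4-ethylphenyl to 2-fluoro-4-methoxyphenyl

A few compounds are considered here, and "the series" means these few. Any claim that something is new, unique, unknown or untested is made for them only; others in the source may bear on it.

Three amides on the shared core have numbers in a functional assay on HeLa cells (Homo sapiens) for antiproliferative activity, read by CCK-8 assay, with a stated time of 72 h; on this read-out lower numbers stand for stronger inhibition and higher numbers for weaker inhibition. Compound 1 `COc1ccc(C(=O)Nc2cccc(-c3oc4cc(-c5ccc(F)cc5)ccc4c(=O)c3O)c2)cc1` gives 4820 nM. Compound 2 `COc1ccccc1C(=O)Nc1cccc(-c2oc3cc(-c4ccc(F)cc4)ccc3c(=O)c2O)c1` gives 14100 nM. Compound 3 `CCc1ccc(C(=O)Nc2cccc(-c3oc4cc(-c5ccc(F)cc5)ccc4c(=O)c3O)c2)cc1` gives 21000 nM, the highest of the three, though its gap to compound 2 is within the scatter and only its gap to compound 1 is beyond it.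

Compound 4 `COc1ccc(C(=O)Nc2cccc(-c3oc4cc(-c5ccc(F)cc5)ccc4c(=O)c3O)c2)c(F)c1` is not yet measured. The change is 2-fluoro-4-methoxyphenyl in place of 4-ethylphenyl on a carbonyl carbon. For the measured compounds named here, two measured steps bear on it. The step of a 4.4-fold higher number from compound 1 to compound 3 (0.64 log units; beyond the scatter) shows that swapping methoxy for ethyl on that aromatic carbon raised the number; compound 4 reverses that swap. The step of a 2.9-fold higher number from compound 1 to compound 2 (0.47 log units; beyond the scatter) shows that moving the methoxy raised the number modestly, which says nothing direct about adding fluorine while keeping the methoxy in place. Going by the values given here, the fluorine contribution has no precedent here.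

Compound 4 is therefore expected to give a lower number than compound 3 in this assay, a step of about a 3.5-fold lower number from compound 3 to compound 4 (0.54 log units; beyond the scatter), landing near compound 1. The estimate for compound 4 is 6000 nM, with a range from 2000 nM to 18000 nM.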

Compound 4, half-maximal inhibitory concentration: 16100 nM
For compound 4 the middle estimate is 2.7-fold (0.43 log units) below the measured one, and the stated range covers the measured number.
By their numbers in this assay, from the lowest: compound 1; then compounds 2, 4 and 3 (each within the scatter of the next).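

In this assay the 4-methoxyphenyl amide does not tolerate added fluorine without loss: fluoro in place of hydrogen on an aromatic carbon gives a 3.3-fold higher number from compound 1 to compound 4 (0.52 log units; beyond the scatter) and so removes the lead that compound 1 holds over the other amides. With the fluorine present, the methoxy no longer separates from the ethyl series, as a 1.3-fold lower number from compound 3 to compound 4 (0.12 log units; within the scatter) and a 1.1-fold higher number from compound 2 to compound 4 (0.06 log units; within the scatter) both lie within the scatter, leaving compound 1 alone with the lowest number of the four. No measurement at hand accounts for this loss.

Open, as far as these compounds go, is whether the loss is particular to fluoro or extends to a chloro or methyl group at that aromatic carbon. Also open, from the compounds shown here alone, is whether a dimethylamino group or a carboxylic acid in place of the methoxy would give a number lower than that of compound 1.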